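A few compounds are considered here, and "the series" means these few. Any claim that something is new, unique, unknown or untested is made for them only; others in the source may bear on it.

Measured so far:
- compound 1, `CN(C)S(=O)(=O)c1cncc(C#Cc2cc(Cl)ccc2OCC(=O)O)c1`, 37 nM
- compound 2, `O=C(O)COc1ccc(Cl)cc1C#Cc1cccnc1`, 117 nM

In an assay on CHO cells for displacement of a labelled ligand from prostaglandin D2 receptor 2 (Homo sapiens), read by scintillation counting (a higher number here means a weaker inhibitor, a lower number a stronger inhibitor), compound 1 gives 37 nM, and compound 2 gives 117 nM. Of the two numbers, compound 2 has the higher one; its nearest neighbour is compound 1, and the step of a 3.2-fold higher number from compound 1 to compound 2 (0.50 log units; beyond the scatter) is a modest one, beyond the scatter. Going by the values given here, that is the only measured step, and it bears directly on the question at hand.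

Compound 3, `O=C(O)COc1ccc(Cl)cc1C#Cc1cncc(S(=O)(=O)N2CCOCC2)c1`, differs from compound 2 in one place: (morpholin-4-yl)sulfonyl in place of hydrogen on an aromatic carbon. The substituent entering here is a sulfonyl group carrying a cyclic amine, set on the same carbon where compound 1 carries its dimethylsulfamoyl group. Since removing that sulfamoyl group from compound 1 raised the number in this assay by a 3.2-fold higher number from compound 1 to compound 2 (0.50 log units; beyond the scatter), putting a related sulfonyl group back is expected to lower it again by a comparable amount. Compound 3 is therefore estimated at 40 nM, in the range 15 nM to 120 nM, corresponding to an expected step of a 2.9-fold lower number from compound 2 to compound 3 (0.47 log units; beyond the scatter).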

Compound 3, inhibition constant: 41 nM
The estimate for compound 3 lay 1.0-fold (0.01 log units) below the measured number; the range from low to high includes it.
By their numbers in this assay, from the lowest: compounds 1 and 3 (each within the scatter of the next); then compound 2.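

In this assay, placing (morpholin-4-yl)sulfonyl on the aromatic carbon two atoms from the ring nitrogen gives a 2.9-fold lower number from compound 2 to compound 3 (0.46 log units; beyond the scatter) and so shows that the lower number seen with the dimethylsulfamoyl group of compound 1 also occurs with a second sulfonyl group, one that carries a six-membered non-aromatic ring. Exchanging dimethylamino for morpholin-4-yl on the sulfonyl sulfur gives a 1.1-fold higher number from compound 1 to compound 3 (0.04 log units; within the scatter) and so adds what compound 1 and compound 2 alone could not show: across this pair, the open dimethylamino group and the morpholine ring cannot be told apart in this assay, even though the ring adds more heavy atoms to the substituent. No measurement is available here that would account for either step.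

As far as these compounds go, two compounds on the sulfonyl sulfur cannot show how widely this holds, so it remains open whether a piperidine ring, a piperazine ring or an unsubstituted amino group there would give a similar number. From the compounds shown here alone, it is also open whether the sulfonyl link itself is needed at this carbon, which a methylsulfonyl group or a carboxamide carrying the same morpholine ring would test.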